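Nitro-substituted Pyridine Analog of a Dihydropyridine Ester

The source may hold more compounds than are shown below. What is called first, only, known or untested is meant among the compounds shown, and "the series" means these compounds.

Measured so far:
compound 1 `CC1=NC(C)=C([N+](=O)[O-])C(c2ncccc2C(F)(F)F)/C1=C(/O)OCCc1ccccc1` — > 59800 nM
compound 2 `CC1=NC(C)=C([N+](=O)[O-])C(c2ncccc2Cl)/C1=C(/O)OCCc1ccccc1` — 5170 nM

Compound 1 reaches only the limit of a functional assay (muscle tissue) with Cavia porcellus as the target (on this read-out lower numbers stand for stronger inhibition and higher numbers for weaker inhibition), as the limit of > 59800 nM in this assay, at which 1 of the 2 values shown sits, records. Among the compounds with values here, compound 2 is the one compound with a measured number, at 5170 nM. Within the data shown here, the single measured step, an at least 11-fold lower number from compound 1 to compound 2 (1.06 log units; beyond the scatter), shows that changing the group on the aromatic ring can move the result a long way. Compound 3 `CC1=NC(C)=C([N+](=O)[O-])C(c2cccc([N+](=O)[O-])n2)/C1=C(/O)OCCc1ccccc1` carries a different change: 6-nitropyridin-2-yl in place of 3-chloropyridin-2-yl on a saturated ring carbon. Among the measured compounds shown here, no measured step involves a nitro group on that ring or a group at that position, so the step from compound 1 to compound 2 gives only a loose guide to its size. Compound 3 is therefore expected to sit near compound 2, with wide uncertainty, at an estimated 12000 nM (range 2500 nM to 59800 nM), an expected step of a 2.3-fold higher number from compound 2 to compound 3 (0.37 log units; beyond the scatter) in this assay.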

Compound 3, half-maximal inhibitory concentration: 4740 nM
For compound 3 the middle estimate is 2.5-fold (0.40 log units) above the measured one, within the range that was stated.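

In this assay, the swap to 6-nitropyridin-2-yl gives a 1.1-fold lower number from compound 2 to compound 3 (0.04 log units; within the scatter), so a chloro group is not the only substituent on this pyridine ring that gives a measurable number. Replacing 3-(trifluoromethyl)pyridin-2-yl with the same nitro-bearing ring gives an at least 12-fold lower number from compound 1 to compound 3 (1.10 log units; beyond the scatter), a second large step that, like the first, starts from compound 1. That starting point is a limit of the assay, not a number: the limit of > 59800 nM in this assay, at which 1 of the 3 values shown sits.

From the compounds shown here alone, in compound 3, the group and its place on the ring change together, and the separate contribution of each remains open. Also unknown is how an amine or a carboxylic acid on this pyridine ring would compare, and whether a nitro group at the ring position held by chloro in compound 2 would give a similar number.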